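A few compounds are considered here, and "the series" means these few. Any claim that something is new, unique, unknown or untested is made for them only; others in the source may bear on it.

In a functional assay on MDA-MB-231 cells (Homo sapiens) for antiproliferative activity, read by MTT assay, with a stated time of 24 h (on this read-out lower numbers stand for stronger inhibition and higher numbers for weaker inhibition), compound 1 `COc1cc(C(=O)/C=C/c2cc(-c3cc(OC)c(OC)c(OC)c3)n3nc(-c4ccccc4)cc3n2)cc(OC)c1OC` gives 24300 nM. In this assay compound 2 `COc1cc(-c2cc(/C=C/C(=O)c3ccc(C)cc3)nc3cc(-c4ccccc4)nn23)cc(OC)c1OC` gives 23900 nM. In this assay compound 3 `COc1cc(-c2cc(C(=O)/C=C/c3ccc(C)cc3)nc3cc(-c4ccccc4)nn23)cc(OC)c1OC` gives 18600 nM.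

Compound 2 and compound 3 have the same atoms joined differently: (2-(4-methylphenyl)ethenyl)carbonyl in place of 2-((4-methylphenyl)carbonyl)ethenyl on an aromatic carbon. The step of a 1.3-fold lower number from compound 2 to compound 3 (0.11 log units; within the scatter). From compound 2 to compound 1 the change is 3,4,5-trimethoxyphenyl in place of 4-methylphenyl on a carbonyl carbon, and the step is a 1.0-fold higher number from compound 2 to compound 1 (0.01 log units; within the scatter). Compound 4 `COc1cc(/C=C/C(=O)c2cc(-c3cc(OC)c(OC)c(OC)c3)n3nc(-c4ccccc4)cc3n2)cc(OC)c1OC` is not yet measured; it differs from compound 3 by 3,4,5-trimethoxyphenyl in place of 4-methylphenyl on a double-bonded chain carbon bound to a double-bonded chain carbon. This is the same kind of change as from compound 2 to compound 1, not the same: there the place was a carbonyl carbon whose other neighbour is a double-bonded chain carbon, here a double-bonded chain carbon bound to a double-bonded chain carbon. Because a 1.0-fold higher number from compound 2 to compound 1 (0.01 log units; within the scatter) was within the scatter, the expected step is a 1.0-fold higher number from compound 3 to compound 4 (0.01 log units; within the scatter). Compound 4 is estimated at 19000 nM in this assay, roughly between 9000 nM and 40000 nM.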

Compound 4, half-maximal inhibitory concentration: 18400 nM
Compound 4: the middle estimate sits 1.0-fold (0.01 log units) above what was measured; measured number inside the range.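

Putting 3,4,5-trimethoxyphenyl in place of 4-methylphenyl on a double-bonded chain carbon bound to a double-bonded chain carbon gives a 1.0-fold lower number from compound 3 to compound 4 (0.00 log units; within the scatter) in this assay. Set beside the same change on the other core, the two steps do not differ: the same change on two cores in this assay, a 1.0-fold higher number (0.01 log units; within the scatter) from compound 2 to compound 1 and a 1.0-fold lower number (0.00 log units; within the scatter) from compound 3 to compound 4, 1.0-fold (0.01 log units) apart, within the scatter of two such steps. This shows that, for these two cores and in this one assay, the change leaves the number within the scatter, but it does not show that the same would hold on any other core or in any other assay.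

The compounds shown leave open whether a different group, such as an amine or a carboxylic acid in place of the 3,4,5-trimethoxyphenyl, would move the number beyond the scatter.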